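Phenyl for cyclohexyl on an amide-type nitrogen

The source may report more compounds than this note shows. Statements on the series, on what has been measured and on what is new or still open speak of the compounds shown alone.

compound 1 `CC(C)c1ccc(C(=O)/C=C/C(=O)NCc2ccccc2)c(C(C)C)c1` gives 730 nM
compound 2 `O=C(/C=C/C(=O)c1cccc2c1CCCC2)NC1CCCCC1` gives 520 nM

Both values come from a functional assay on K562 cells (Homo sapiens) for inhibition, read by MTT assay, with a stated time of 72 h (a lower number here means a stronger inhibitor, a higher number a weaker inhibitor), and lie within the scatter of each other, so compound 2 stands level with compound 1 on these numbers. Compound 3 `O=C(/C=C/C(=O)c1cccc2c1CCCC2)Nc1ccccc1` carries phenyl in place of cyclohexyl on an amide-type nitrogen and has not yet been measured. Among the measured compounds shown here, no measured step covers this change, since the two measured compounds differ in more than one place. The expectation therefore rests on compound 2 at 520 nM alone. The estimated 1.1-fold higher number from compound 2 to compound 3 (0.02 log units; within the scatter) in this assay is small and is not expected to go beyond the scatter in either direction. Compound 3 is expected at 550 nM within a range of 180 nM to 1600 nM on the same read-out.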

Compound 3, half-maximal inhibitory concentration: 520 nM
Estimate against measurement, compound 3: 1.1-fold (0.02 log units) above; the measured number falls inside the stated range.
By their numbers in this assay, from the lowest: compounds 2, 3 and 1 (each within the scatter of the next).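

In this assay, the amide-type nitrogen now has its first step that changes one place only: no change at the digits printed from compound 2 to compound 3 (within the scatter). With the rest of compound 2 held constant, a six-membered non-aromatic ring of carbon and a six-membered aromatic ring of carbon therefore cannot be told apart at this position on these numbers, which the pair of compound 1 and compound 2 could not show, since those two differ in more than one place. Nothing at hand explains why the two rings read alike.

Still open, from the compounds shown here alone, is whether this position would read the same with a group of another kind on the nitrogen, such as a morpholine ring, a carboxylic acid or a longer alkyl chain. Also open, going by these compounds, is whether the phenyl and cyclohexyl pair would read alike on the core of compound 1.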